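The source may hold more compounds than are shown below. What is called first, only, known or untested is meant among the compounds shown, and "the series" means these compounds.

Measured so far in a functional assay on HepG2 cells (Homo sapiens) for antiproliferative activity, read by MTT assay, with a stated time of 48 h; a higher number here means a weaker inhibitor of growth, a lower number a stronger inhibitor of growth:
compound 1 `CCOC(=O)N1N=C(c2ccccc2)CC1c1cc(OC)c(OC)c(OC)c1` gives 5950 nM
compound 2 `CCCOC(=O)N1N=C(c2ccccc2)CC1c1cc(OC)c(OC)c(OC)c1` gives the limit > 10000 nM
compound 3 `COc1cc(C2CC(c3ccccc3)=NN2C(=O)OCc2ccccc2)cc(OC)c1OC` gives the limit > 10000 nM

Within the data shown here, compound 1 holds the only number of the three; the other two values are limits, (the limit of > 10000 nM in this assay, at which 2 of the 3 values shown sit). The measured steps are an at least 1.6-fold higher number from compound 1 to compound 2 (0.22 log units; that floor lies within the scatter), an at least 1.6-fold higher number from compound 1 to compound 3 (0.22 log units; that floor lies within the scatter) and a step that the two limits leave unreadable from compound 2 to compound 3, all on the chain bound to the oxygen next to the carbonyl.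

Compound 4 `CCOC(=O)N1N=C(c2cccc(OC)c2)CC1c1cc(OC)c(OC)c(OC)c1` differs from compound 1 by methoxy in place of hydrogen on an aromatic carbon. Among the measured compounds shown here, no measured step touches that ring, so none bears on this change, and no step beyond the scatter is expected in this assay. Compound 4 is therefore estimated at 5500 nM, between 2000 nM and 15000 nM, an expected 1.1-fold lower number from compound 1 to compound 4 (0.03 log units; within the scatter).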

Compound 4, concentration for 50% growth inhibition: 5820 nM
Estimate against measurement, compound 4: 1.1-fold (0.02 log units) below, within the range that was stated.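

In this assay the change from phenyl to 3-methoxyphenyl gives a 1.0-fold lower number from compound 1 to compound 4 (0.01 log units; within the scatter) and so stays within the scatter. Among these compounds, this is the first reading on this ring, since the earlier compounds varied only the ethyl chain, and it shows that a methoxy group on this aromatic carbon leaves the growth-inhibition reading of compound 1 in place. No data shown here account for this result.

Open, from the compounds shown here alone, is whether an amine, a carboxylic acid or a longer alkoxy chain on this ring would also leave the reading in place. Also open, going by these compounds, is whether any change on this ring can bring the reading clear of the scatter.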